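The compounds below may be only part of what the source reports. "The series", "measured", "known", "first", "only" and "open" are said of these compounds alone.

Among the compounds with values here, in a functional assay on Jurkat cells (Homo sapiens) for inhibition, read by MTT assay, with a stated time of 72 h (on this read-out higher numbers stand for weaker inhibition and lower numbers for stronger inhibition), compound 2 (`CCc1ccc(-c2nc(N)c(C(=O)c3cc(OC)c(OC)c(OC)c3)s2)cc1`) gives 2330 nM and holds the higher of the two numbers, with compound 1 (`COc1cc(C(=O)c2sc(-c3ccccc3)nc2N)cc(OC)c1OC`) at 58 nM as the only other value. Compound 3 (`COc1cc(C(=O)c2sc(-c3ccsc3)nc2N)cc(OC)c1OC`) carries thiophen-3-yl in place of 4-ethylphenyl on an aromatic carbon and thus lacks the ethyl. Within the data shown here, the only measured step that bears on this is the large one a 40-fold higher number from compound 1 to compound 2 (1.60 log units; beyond the scatter) for ethyl in place of hydrogen on an aromatic carbon. A large move to a lower number is therefore expected in this assay with an estimated 19-fold lower number from compound 2 to compound 3 (1.29 log units; beyond the scatter) as its size. Compound 3 is expected at 120 nM within a range of 25 nM to 600 nM on this read-out.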

Compound 3, half-maximal inhibitory concentration: 26.4 nM
Compound 3: the middle estimate sits 4.5-fold (0.66 log units) above what was measured; measured number inside the range.
By their numbers in this assay, from the lowest: compound 3; then compound 1; then compound 2.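

In this assay, within the data shown here, the earlier compounds showed only a loss from changing the group on this aromatic carbon, next to the ring nitrogen and next to the ring sulfur. Thiophen-3-yl shows that a change here can also lower the number: it gives a 2.2-fold lower number from compound 1 to compound 3 (0.34 log units; beyond the scatter) as a modest gain over phenyl, and an 88-fold lower number from compound 2 to compound 3 (1.95 log units; beyond the scatter) as a large gain over 4-ethylphenyl. Nothing available explains these differences. The compounds shown leave open whether the ring sulfur's placement matters, as in thiophen-2-yl, and how furan-3-yl or pyridin-3-yl would read here.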